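Ester methyl to ethyl: what to expect for compound 4

This account rests on a few compounds, and the source may have more. Where it says the series, first, only, none or still open, it means among the compounds named here.

compound 1 `COC(=O)c1ccccc1OCC(O)CNC(C)C`: 12.6 nM
compound 2 `COC(=O)c1ccccc1OCC(O)CNC(C)(C)C`: 1.26 nM
compound 3 `COC(=O)c1ccccc1OCC(O)CNC(C)(C)CNC(N)=O`: 3.16 nM

All three were tested in a functional assay (trachea) for inhibition, with Cavia porcellus as the target; a lower number here means tighter binding, a higher number weaker binding. Compound 2 differs from compound 1 in one place: methyl in place of hydrogen on a saturated chain carbon bound to an amine nitrogen and two saturated chain carbons. That change gave a 10-fold lower number from compound 1 to compound 2 (1.00 log units; beyond the scatter). Compound 3 differs from compound 1 by ureidomethyl in place of hydrogen on a saturated chain carbon bound to an amine nitrogen and two saturated chain carbons, and this is also how the core of compound 3 differs from the core of compound 1; the step was a 4.0-fold lower number from compound 1 to compound 3 (0.60 log units; beyond the scatter). Between the two larger compounds the step was a 2.5-fold higher number from compound 2 to compound 3 (0.40 log units; beyond the scatter).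

Compound 4 `CCOC(=O)c1ccccc1OCC(O)CNC(C)(C)CNC(N)=O` has not been measured. It differs from compound 3 by methyl in place of hydrogen on a saturated chain carbon bound to an oxygen next to a carbonyl group. This is the same kind of change as from compound 1 to compound 2, methyl in place of hydrogen, but not the same: there it sat on a saturated chain carbon bound to an amine nitrogen and two saturated chain carbons, here on a saturated chain carbon bound to an oxygen next to a carbonyl group. Among the measured compounds shown here, no measured pair tests a change at that place, so the earlier step cannot simply be carried over. A small step is expected from compound 3 to compound 4 in this assay, a 1.3-fold lower number from compound 3 to compound 4 (0.10 log units; within the scatter). Compound 4 is estimated at 2.5 nM, with a likely range from 0.8 nM to 8 nM.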

Compound 4, dissociation constant: 0.501 nM
Estimate against measurement, compound 4: 5.0-fold (0.70 log units) above; the whole stated range lies above it.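

In this assay, going from methoxycarbonyl to ethoxycarbonyl gave a 6.3-fold lower number from compound 3 to compound 4 (0.80 log units; beyond the scatter), a step of about the same size as the earlier methyl step in the series: the same change on two cores in this assay, a 10-fold lower number (1.00 log units; beyond the scatter) from compound 1 to compound 2 and a 6.3-fold lower number (0.80 log units; beyond the scatter) from compound 3 to compound 4, 1.6-fold (0.20 log units) apart, within the scatter of two such steps. Within these compounds, then, methyl in place of hydrogen lowered the number to a similar extent on both cores, even though it sat on a saturated chain carbon bound to an amine nitrogen and two saturated chain carbons in one case and on a saturated chain carbon bound to an oxygen next to a carbonyl group in the other. Among the compounds shown here, these are only two steps at two different places, so they do not show that a step at one place predicts a step at the other, or that the match would hold on further cores.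

Going by these compounds, whether ethoxycarbonyl gives a like step on the cores of compound 1 and compound 2 remains open. So does the outcome with a longer chain on the ester oxygen, or with a carboxylic acid or an amide in place of the ester.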